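The source may hold more compounds than are shown below. What is called first, only, known or untested is meant among the compounds shown, and "the series" means these compounds.

Series notes. Compound 1 `CC(=O)c1ccc(OCCCN2CCN(c3ncccn3)CC2)cc1` gives 53.2 nM in a functional assay on L5178Y cells (Mus musculus) for antiproliferative activity, read by MTT assay; a lower number here means a stronger inhibitor, a higher number a weaker inhibitor. Compound 2 `CC(C)(C)c1ccc(OCCCN2CCN(c3ncccn3)CC2)cc1` carries tert-butyl in place of acetyl on an aromatic carbon and gives 25.6 nM in this assay; the resulting step is a 2.1-fold lower number from compound 1 to compound 2 (0.32 log units; beyond the scatter). Compound 3 `CC(=O)c1ccc(OCCCCN2CCN(c3ncccn3)CC2)cc1` gives 31.6 nM in this assay; how its core differs from the core of compound 1 is not broken down here, and the two values lie within the usual scatter of each other. Compound 4 `CC(C)(C)c1ccc(OCCCCN2CCN(c3ncccn3)CC2)cc1` is not yet measured in this assay. Relative to compound 3 it carries tert-butyl in place of acetyl on an aromatic carbon, the same change at the same place as the one made between compound 1 and compound 2. The expected step is a 2.0-fold lower number from compound 3 to compound 4 (0.30 log units; within the scatter), set beside a 2.1-fold lower number from compound 1 to compound 2 (0.32 log units; beyond the scatter), resting on that single measured instance. Compound 4 is therefore expected to give 16 nM in this assay, with a likely range from 8 nM to 35 nM.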

Compound 4, half-maximal inhibitory concentration: 11.3 nM
For compound 4 the middle estimate is 1.4-fold (0.15 log units) above the measured one; the range from low to high includes it.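

On the core of compound 3, tert-butyl in place of acetyl on an aromatic carbon gives a 2.8-fold lower number from compound 3 to compound 4 (0.45 log units; beyond the scatter) in this assay. The change therefore carries over in the same direction, and the sizes of the two steps cannot be told apart: the same change on two cores in this assay, a 2.1-fold lower number (0.32 log units; beyond the scatter) from compound 1 to compound 2 and a 2.8-fold lower number (0.45 log units; beyond the scatter) from compound 3 to compound 4, 1.3-fold (0.13 log units) apart, within the scatter of two such steps. For the compounds shown here, this rests on only two cores and shows neither why the change lowers the number nor whether it would hold on any other core.

Open, as far as these compounds go, is whether other groups on this aromatic carbon, such as an amine, a carboxylic acid or trifluoromethyl, would lower the number as tert-butyl does. Going by these compounds alone, also open is whether the same step would appear with a longer chain than the one in compound 3.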